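This account rests on a few compounds, and the source may have more. Where it says the series, first, only, none or still open, it means among the compounds named here.

Compound 1 `Cc1[nH]c2ccccc2c(=O)c1Cc1ccccc1`: > 40100 nM, a limit
Compound 2 `COc1ccc2[nH]c(C)c(Br)c(=O)c2c1`: > 37300 nM, a limit
Compound 3 `COc1cccc2[nH]c(C)c(Cc3ccccc3)c(=O)c12`: 11200 nM

Among the measured compounds shown here, in an ADME assay on J774 cells (Mus musculus) for cytotoxicity (a higher number here means that more compound is needed for the effect, a lower number that less compound is needed), compound 3 gives 11200 nM, the only actual number in the set. The other two values are limits.

The next compound is compound 4 `Cc1[nH]c2cccc(Cl)c2c(=O)c1Cc1ccccc1`, with chloro in place of methoxy on an aromatic carbon.

For the measured compounds named here, only one measured step bears on this change: an at least 3.5-fold lower number from compound 1 to compound 3 (0.55 log units; beyond the scatter). There, methoxy took the place of hydrogen on an aromatic carbon, and the size is only a minimum. Going by the values given here, no measured step covers chloro, and compound 2 differs from compound 4 in more than one place. Compound 4 still carries a group other than hydrogen on that carbon, so in this assay a large return towards compound 1 is not expected. The expected change is small, probably within the scatter and towards a slightly higher number: a 1.3-fold higher number from compound 3 to compound 4 (0.13 log units; within the scatter). For compound 4 the estimated value is 15000 nM, with an expected range of 6000 nM to 40000 nM.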

Compound 4, half-maximal effective concentration in the J774 assay: > 35200 nM
Compound 4: only a limit was reported; the forecaster's own chance of this, stated with the estimate: 25%; at least 2.3-fold (0.37 log units) between middle value and limit.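

In the J774 assay, chloro in place of methoxy on this aromatic carbon gives an at least 3.1-fold higher number from compound 3 to compound 4 (0.49 log units; beyond the scatter), so a group other than hydrogen on this carbon is not enough to give the lower number seen with methoxy. The step from compound 1 to compound 4 cannot be read, as both values are limits. In a physicochemical assay for lipophilicity, at pH 7.4 (a higher number here means a more lipophilic compound, a lower number a more polar compound), compound 3 gives 2.11 and compound 4 gives 2.65. In the physicochemical assay the same change gives a number 0.54 log units higher from compound 3 to compound 4 (beyond the scatter), so within this pair the more lipophilic compound is the one that needs more compound in the J774 assay: the measured distribution coefficient of compound 3, 2.11, and of compound 4, 2.65, a number 0.54 log units higher (beyond the scatter)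

As far as these compounds go, whether the lower number of compound 3 depends on methoxy itself or on any oxygen-linked group on this carbon stays open, and a hydroxy or ethoxy group there would bear on this. From the compounds shown here alone, with only a limit for compound 4, the full size of the step also stays open.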